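A few compounds are considered here, and "the series" means these few. Any claim that something is new, unique, unknown or untested is made for them only; others in the source may bear on it.

Measured compounds:
compound 1 `ClCc1cccc(Cn2cnc3ncnc(Cl)c32)c1` with 1230 nM
compound 2 `ClCc1ccccc1Cn1cnc2ncnc(Cl)c21` with 5010 nM
compound 3 `Nc1nc(Cl)c2ncn(Cc3cccc(CCl)c3)c2n1` with 2040 nM

Of the compounds shown here, three have been measured in a functional assay on NCI-H23 cells (Homo sapiens) for cytotoxicity, read by sulforhodamine B assay, with a stated time of 48 h; a higher number here means a weaker inhibitor of growth, a lower number a stronger inhibitor of growth. Compound 2 gives the highest number of the three; its nearest neighbour is compound 3, and the gap to compound 1 is wider still, both beyond the scatter. Compound 1 and compound 3 lie within the scatter of each other, so the amino group in compound 3 makes no readable difference against the hydrogen in compound 1 at the same position.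

Compound 4 `ClCc1ccccc1Cn1cnc2nc(Cl)nc(Cl)c21` has not been measured. It differs from compound 2 by chloro in place of hydrogen on an aromatic carbon. Going by the values given here, no measured pair tests this particular change. Among the compounds with values here, the only related comparison, compound 1 against compound 3, shows that substitution at this position need not shift the number; an expected small step from compound 2 to compound 4 is therefore a 1.4-fold lower number from compound 2 to compound 4 (0.16 log units; within the scatter) in this assay, not beyond the scatter. Compound 4 is expected to give 3500 nM, with a range from 1200 nM to 10000 nM.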

Compound 4, concentration for 50% growth inhibition: 19100 nM
Beside the measured number, compound 4's estimate is 5.5-fold (0.74 log units) below it; the measured number lies above the stated range.
By their numbers in this assay, from the lowest: compounds 1 and 3 (each within the scatter of the next); then compound 2; then compound 4.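

In this assay, chloro in place of hydrogen on the aromatic carbon between two ring nitrogen atoms gives a 3.8-fold higher number from compound 2 to compound 4 (0.58 log units; beyond the scatter), so this position is not indifferent to substitution. The earlier compounds shown here showed only that hydrogen and amino at this position, on a different parent, lie within the scatter of each other; here a single added chlorine atom moves the number beyond the scatter, towards weaker inhibition of growth. The compounds shown offer no explanation for this step.

Going by these compounds, whether a methyl or a methoxy group at this carbon would raise the number as chloro does remains open. So does whether chloro would have the same effect on the parent shared by compound 1 and compound 3.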